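Swapping the benzyl arm for a hydroxypropyl chain

The compounds below may be only part of what the source reports. "The series", "measured", "known", "first", "only" and "open" are said of these compounds alone.

Compound 1 `CCCCCn1c(-c2ccccc2)nc2c(NCc3ccccc3)nccc21` gives > 200000 nM in an assay on isolated protein for inhibition of high affinity 3',5'-cyclic-AMP phosphodiesterase 7A (Homo sapiens), read by cAMP accumulation, with a stated time of 20 min (on this read-out higher numbers stand for weaker inhibition and lower numbers for stronger inhibition), a limit of the assay.
Compound 2 `CCCCCn1c(-c2ccco2)nc2c(NCc3ccccc3)nccc21` gives > 200000 nM in this assay, also a limit.
Compound 3 `COCCNc1nccc2c1nc(-c1ccco1)n2C1CCCC1` gives 192000 nM in this assay.

Compound 1 therefore has no number of its own, only a limit, and it sits at the limit of > 200000 nM in this assay, at which 2 of the 3 values shown sit. Within the data shown here, the one measured step, a step that the two limits leave unreadable from compound 1 to compound 2, cannot be sized. Compound 4 `CCCCCn1c(-c2ccccc2)nc2c(NCCCO)nccc21` differs from compound 1 by 2-hydroxyethyl in place of phenyl on a saturated chain carbon bound to a nitrogen on an aromatic ring. Among the measured compounds shown here, no measured step tracks this change. Compound 3, which also lacks the benzyl group, gives 192000 nM. For compound 4 the expected step of a number no higher from compound 1 to compound 4 (the limit leaves the size open) is none beyond the scatter, most likely ending again at the limit. Compound 4 is estimated at 200000 nM with a range from 100000 nM to 500000 nM.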

Compound 4, half-maximal inhibitory concentration: > 200000 nM
Compound 4 gave a limit, no number (the forecaster's own chance of this, stated with the estimate: 70%); the middle value sits exactly at the limit.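

Among these compounds, compound 1 and compound 4 both stop at a limit of the assay, so no step between them can be read: the limit of > 200000 nM in this assay, at which 3 of the 4 values shown sit.

Going by these compounds, whether 3-hydroxypropyl in place of benzyl changes the inhibition at all remains open.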